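Pyrimidin-2-yl on the sulfonamide of compound 2

The compounds below may be only part of what the source reports. "The series", "measured", "known", "first", "only" and "open" are said of these compounds alone.

Of the compounds shown here, two have numbers so far in an ADME assay on the whole organism (Mus musculus, strain BALB/c) for pharmacokinetics, read by LC-MS, with a stated time of 24 h, at a dose of 1 mg/kg by the intravenous route; a higher number here means that more of the compound sits outside the plasma, a lower number that more of the compound stays in the plasma. Compound 2 (`Cn1nccc1-c1cc(C(F)(F)F)ccc1[C@H]1CCOc2cc(S(=O)(=O)Nc3nccs3)ccc21`) stands highest of the two at 2.2 L/kg and compound 1 (`O=S(=O)(Nc1ncccn1)c1ccc2c(c1)OCC[C@@H]2c1ccc(C(F)(F)F)cc1-c1ccc(F)nc1`) gives the lower number at 0.8 L/kg with the gap beyond the scatter. These two compounds differ in more than one place, so their gap cannot be assigned to any single change.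

Compound 3 (`Cn1nccc1-c1cc(C(F)(F)F)ccc1[C@H]1CCOc2cc(S(=O)(=O)Nc3ncccn3)ccc21`) keeps the rest of compound 2 and changes one group, with pyrimidin-2-yl in place of 1,3-thiazol-2-yl on a sulfonamide nitrogen. Within the data shown here, the only measured compound carrying pyrimidin-2-yl at that place is compound 1 at 0.8 L/kg and this single comparison is the whole basis for the expected direction. Among the measured compounds shown here, no measured pair isolates the change, so the expectation is weak. A modest fall is expected, estimated as a 1.6-fold lower number from compound 2 to compound 3 (0.20 log units; within the scatter) and probably not beyond the scatter. Compound 3 is expected at 1.4 L/kg in this assay (estimated range 0.7 L/kg to 2.6 L/kg).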

Compound 3, volume of distribution at steady state: 0.9 L/kg
The estimate for compound 3 lay 1.6-fold (0.19 log units) above the measured number; measured number inside the range.
By their numbers in this assay, from the lowest: compounds 1 and 3 (each within the scatter of the next); then compound 2.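

In this assay, the sulfonamide nitrogen now has a change read on its own: with the rest of the molecule held fixed, pyrimidin-2-yl in place of 1,3-thiazol-2-yl gives a 2.4-fold lower number from compound 2 to compound 3 (0.39 log units; beyond the scatter). With pyrimidin-2-yl held at that nitrogen, 1-methyl-1H-pyrazol-5-yl in place of 6-fluoropyridin-3-yl on an aromatic carbon gives a 1.1-fold higher number from compound 1 to compound 3 (0.05 log units; within the scatter), so this exchange does not separate the two compounds, and in this small set the number follows the group on the sulfonamide nitrogen. No measurement shown speaks to what lies behind the step at the sulfonamide nitrogen.

The compounds shown leave open whether that step keeps its size with 6-fluoropyridin-3-yl rather than 1-methyl-1H-pyrazol-5-yl on the aromatic carbon. Also open, on these data alone, is how a group of another kind on the sulfonamide nitrogen, such as a short alkyl chain or a ring carrying an amine or a carboxylic acid, would read in this assay.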